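A few compounds are considered here, and "the series" means these few. Any claim that something is new, unique, unknown or untested is made for them only; others in the source may bear on it.

Measured so far in a functional assay on KB cells (Homo sapiens) for antiproliferative activity, read by sulforhodamine B assay, with a stated time of 3 days; on this read-out lower numbers stand for an effect already at smaller amounts and higher numbers for an effect only at larger amounts of compound:
- compound 1 `CCC1=C(O)c2c(oc(-c3cccc(C)c3)cc2=O)C(CC)(CC)C1=O`: 49.7 uM
- compound 2 `CCC1=C(O)c2c(oc(-c3cccc(C(F)(F)F)c3)cc2=O)C(CC)(CC)C1=O`: 35.7 uM
- compound 3 `CCC1=C(O)c2c(oc(-c3cccc(OC(F)(F)F)c3)cc2=O)C(CC)(CC)C1=O`: a limit of the assay, > 47.4 uM

Compound 1 gives the highest of the two readable numbers; its nearest neighbour is compound 2, with a 1.4-fold lower number from compound 1 to compound 2 (0.14 log units; within the scatter). Compound 3 sits at a limit, (the limit of > 47.4 uM in this assay, at which 1 of the 3 values shown sits), so its value is not a number. The step that the limit leaves unreadable from compound 1 to compound 3 is therefore not readable, and an at least 1.3-fold higher number from compound 2 to compound 3 (0.12 log units; that floor lies within the scatter) shows only a floor that stays within the scatter.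

The next compound, compound 4 `CCC1=C(O)c2c(oc(-c3ccc(OC)cc3C)cc2=O)C(CC)(CC)C1=O`, changes the same phenyl ring as the measured steps: 4-methoxy-2-methylphenyl in place of 3-methylphenyl on an aromatic carbon. Every measured change on that ring, from methyl to trifluoromethyl or to trifluoromethoxy, moved the read-out by no more than the scatter allows, or gave a limit. For the measured compounds named here, no measured step covers a methoxy group or a second substituent on the ring, so the expectation rests on the small spread seen so far: a step of about a 1.1-fold lower number from compound 1 to compound 4 (0.04 log units; within the scatter) is expected, not beyond the scatter. For compound 4 the estimated value in this assay is 45 uM, with a range from 20 uM to 100 uM, and a real chance that only a limit is reported.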

Compound 4, concentration for half-maximal effect: 20.9 uM
The estimate for compound 4 lay 2.2-fold (0.33 log units) above the measured number; low and high end bracket the measured number.
By their numbers in this assay, from the lowest: compounds 4, 2 and 1 (each within the scatter of the next, the first and the last beyond it).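

In this assay, the aryl group on the carbon next to the ring oxygen proves able to shift the read-out beyond the scatter, though only modestly: a 2.4-fold lower number from compound 1 to compound 4 (0.38 log units; beyond the scatter). For the compounds shown here, the earlier exchanges of the single methyl group for trifluoromethyl or trifluoromethoxy did not show this, giving either a step within the scatter or a limit. The change from 3-methylphenyl to 4-methoxy-2-methylphenyl alters the place of the methyl group and adds a methoxy group at once, so the step cannot be assigned to either part.

Compound 3 remains a limit and not a number, so its steps cannot be read: the limit of > 47.4 uM in this assay, at which 1 of the 4 values shown sits.
Still open, on these data alone, are whether 4-methoxyphenyl or 2-methylphenyl alone would carry the step, and how an amine or a carboxylic acid on this ring would read.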